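Imidazopyrazine series: A498 growth inhibition, aryl variation

The source may hold more compounds than are shown below. What is called first, only, known or untested is meant among the compounds shown, and "the series" means these compounds.

Measured so far:
compound 1 `c1ccc2c(-c3cn4ccnc4c(-c4ccc5ncn(C6CCCCC6)c5c4)n3)cccc2c1`: 14%
compound 2 `Cc1cccc(-c2cn3ccnc3c(-c3ccc4ncn(Cc5ccccc5)c4c3)n2)c1`: 22.1%
compound 3 `O=Cc1ccc(-c2cn3ccnc3c(-c3ccc4ncn(Cc5ccccc5)c4c3)n2)cc1`: 11.2%

In a functional assay on A498 cells (Homo sapiens) for inhibition, read by sulforhodamine B assay, with a stated time of 48 h, tested at 10 uM (on this read-out lower numbers stand for less inhibition and higher numbers for more inhibition at the one concentration tested (going by the name of the read-out)), compound 3 gives the lowest of the three numbers; it sits within the scatter of compound 1 and beyond the scatter only of compound 2. Compound 4 `c1ccc(Cn2cnc3ccc(-c4nc(-c5cccc6ccccc56)cn5ccnc45)cc32)cc1` differs from compound 3 in one place: naphthalen-1-yl in place of 4-formylphenyl on an aromatic carbon. Among the compounds with values here, the one measured step that bears on this position is a number 10.9 percentage points lower from compound 2 to compound 3 (beyond the scatter), so exchanging one aryl group for another here has moved the read-out modestly. Compound 1 also carries naphthalen-1-yl and gives 14%, close to compound 3. Compound 4 is therefore expected to stay near compound 3, with the step from compound 3 to compound 4 estimated as a number 4.8 percentage points higher from compound 3 to compound 4 (within the scatter), inside the scatter. The estimate for compound 4 is 16%, expected between 5% and 30%.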

Compound 4, a percentage reported as inhibition, at one concentration (the size of the read-out at that concentration, not a potency): 6.74%
Compound 4: the middle estimate sits 9.3 percentage points above what was measured; low and high end bracket the measured number.
By their numbers in this assay, from the lowest: compounds 4, 3, 1 and 2 (each within the scatter of the next, the first and the last beyond it).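

In this assay the step of a number 4.5 percentage points lower from compound 3 to compound 4 (within the scatter) does not separate naphthalen-1-yl from 4-formylphenyl on this aromatic carbon, while the step of a number 15.4 percentage points lower from compound 2 to compound 4 (beyond the scatter) sets naphthalen-1-yl apart from 3-methylphenyl, as 4-formylphenyl already was. With naphthalen-1-yl held, the step of a number 7.3 percentage points lower from compound 1 to compound 4 (within the scatter) does not separate benzyl from cyclohexyl on the aromatic nitrogen. Nothing at hand speaks to the cause of these numbers.

Open, going by these compounds, is whether any group on this aromatic carbon, such as an aminomethyl or carboxylic acid on the phenyl ring, would give a number beyond that of compound 2.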